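Working notes: chain lengthening from compound 3 to compound 4

This account rests on a few compounds, and the source may have more. Where it says the series, first, only, none or still open, it means among the compounds named here.

Measured in a functional assay on SW-620 cells (Homo sapiens) for cytotoxicity, read by MTT assay, with a stated time of 48 h; a higher number here means a weaker inhibitor, a lower number a stronger inhibitor:
compound 1, `CCCCCCCCCCCCCCNC(=O)[C@@H](N)[C@@H](C)O`: 18700 nM
compound 2, `CCCCCCCCCCCCCCNC(=O)[C@@H](NC(=O)c1ccccc1)[C@@H](C)O`: 200000 nM
compound 3, `CCCCCCCCCCCCCCNC(=O)[C@@H](NS(=O)(=O)c1cccs1)[C@@H](C)O`: 18400 nM

Compound 3 has the lowest number of the three, but its gap to compound 1 is within the scatter (a 1.0-fold lower number from compound 1 to compound 3 (0.01 log units; within the scatter)), while it stands well apart from compound 2 (an 11-fold lower number from compound 2 to compound 3 (1.04 log units; beyond the scatter)). Compound 4, `CCCCCCCCCCCCCCCCCCNC(=O)[C@@H](NS(=O)(=O)c1cccs1)[C@@H](C)O`, differs from compound 3 by butyl in place of hydrogen on a saturated chain carbon, ten or more bonds along the chain from an amide-type nitrogen. The measured steps, an 11-fold higher number from compound 1 to compound 2 (1.03 log units; beyond the scatter) and an 11-fold lower number from compound 2 to compound 3 (1.04 log units; beyond the scatter), both concern groups on the amine nitrogen, not the saturated chain, so none bears on this change. No step beyond the scatter is therefore expected in this assay. Compound 4 is expected to give 18000 nM (6000 nM to 55000 nM). The expected step is a 1.0-fold lower number from compound 3 to compound 4 (0.01 log units; within the scatter).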

Compound 4, half-maximal inhibitory concentration: > 200000 nM
Compound 4: no number, only a limit; the forecaster's own chance of this, stated with the estimate: 10%; middle value at least 11-fold (1.04 log units) from the limit.
By their numbers in this assay, from the lowest: compounds 3 and 1 (each within the scatter of the next); then compound 2.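

For the compounds shown here, the saturated chain, untouched in the earlier steps, which concern only the amine nitrogen, proves a sensitive position in this assay: butyl in place of hydrogen on this chain gives an at least 10-fold higher number from compound 3 to compound 4 (1.03 log units; beyond the scatter). For compound 4, > 200000 nM is a limit of the assay and not a number: the limit of > 200000 nM in this assay, at which 1 of the 4 values shown sits.

Open, going by these compounds, is whether a shorter chain would keep the value of compound 3 or move it. Also open, on these data alone, is whether a carboxylic acid or an amine on the chain would be tolerated at this position.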